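The source may hold more compounds than are shown below. What is called first, only, known or untested is meant among the compounds shown, and "the series" means these compounds.

Measured so far in a toxicity assay on the whole organism (strain Icem-CET (SPF Caw)) for cytotoxicity, with Mus musculus as the target; a lower number here means that less compound is needed, a higher number that more compound is needed for the effect:
- compound 1 `C=CCNC(=O)/C(C)=C(\C)c1ccc(C)cc1`: 100 mg/kg
- compound 2 `C/C(C(=O)NC1CC1)=C(/C)c1ccc(C)cc1`: 110 mg/kg
- compound 3 `C=CCNC(=O)/C(C)=C(/C)c1ccc(C)cc1`: 280 mg/kg

Compound 1 and compound 2 lie within the scatter of each other, the step being a 1.1-fold higher number from compound 1 to compound 2 (0.04 log units; within the scatter) for cyclopropyl in place of allyl on an amide-type nitrogen. Compound 3 is set apart by a 2.8-fold higher number from compound 1 to compound 3 (0.45 log units; beyond the scatter), a step that rests on (the fact that compounds 1 and 3 differ only in the configuration as drawn).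

Compound 4 `C=CCNC(=O)/C(C)=C(\C)c1ccc(Cl)cc1` is the next case. Change from compound 1: chloro in place of methyl on an aromatic carbon. Neither measured step touches the aromatic ring; one alters the amide nitrogen substituent, the other the double bond configuration. Within the data shown here, no measured step therefore bears on this change, and a step within the scatter is expected in this assay. Compound 4 is estimated at 100 mg/kg, range 45 mg/kg to 220 mg/kg, that is no change at the digits printed from compound 1 to compound 4 (within the scatter) expected.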

Compound 4, dose for half-maximal effect: 70 mg/kg
Estimate against measurement, compound 4: 1.4-fold (0.15 log units) above; the range from low to high includes it.
By their numbers in this assay, from the lowest: compounds 4, 1 and 2 (each within the scatter of the next); then compound 3.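

In this assay, among these compounds, chloro in place of methyl on an aromatic carbon, para to a large group, gives a 1.4-fold lower number from compound 1 to compound 4 (0.15 log units; within the scatter), the first reading at this ring position. Unlike the double bond configuration, this swap does not set the compound apart from compound 1. Nothing available bears on this ring change.

Open, on these data alone, is whether an amine, a carboxylic acid or a methoxy group on the same aromatic carbon would step beyond the scatter. Also open, as far as these compounds go, is whether chloro behaves alike with the double bond of compound 3 or the cyclopropyl of compound 2.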